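Aryl swap on the ring nitrogen: compound 3 to compound 4

A few compounds are considered here, and "the series" means these few. Any claim that something is new, unique, unknown or untested is made for them only; others in the source may bear on it.

Measured so far:
compound 1, `Cc1ccc(-c2nc(CNc3ccc(C(=O)NO)cc3)n(-c3ccccc3)n2)o1`: 60.7%
compound 2, `Cc1cccc(-c2nc(CNc3ccc(C(=O)NO)cc3)n(-c3ccccc3)n2)c1`: 64.1%
compound 3, `O=C(NO)c1ccc(NCc2nc(-c3ccccc3)nn2-c2cccc(Cl)c2)cc1`: 62.3%

These three numbers come from an assay on Sf9 cells for inhibition of protein deacetylase HDAC6 (Homo sapiens), read by fluorescence, with a stated time of 40 min, tested at 100 nM; a higher number here means more inhibition at the concentration tested (going by the name of the read-out), a lower number less inhibition. Compound 3 stands second highest of the three, with compound 1 nearest, a number lower within the scatter, and compound 2 furthest, a number higher within the scatter. Compound 4, `O=C(NO)c1ccc(NCc2nc(-c3ccccc3)nn2-c2ccc(C(F)(F)F)cc2)cc1`, is not yet measured; it differs from compound 3 by 4-(trifluoromethyl)phenyl in place of 3-chlorophenyl on an aromatic nitrogen. Among the measured compounds shown here, the only measured step, a number 3.4 percentage points higher from compound 1 to compound 2 (within the scatter), concerns a group on an aromatic carbon, not the aromatic nitrogen, so it bears on the change only loosely; it lay within the scatter. Compound 4 is therefore expected to differ from compound 3 by a number 1.3 percentage points lower from compound 3 to compound 4 (within the scatter), nothing beyond the scatter. Compound 4 is estimated at 61%, between 47% and 74%.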

Compound 4, a percentage reported as inhibition, at one concentration (the size of the read-out at that concentration, not a potency): 38.9%
Estimate against measurement, compound 4: 22.1 percentage points above; measured number below the stated range.
By their numbers in this assay, from the lowest: compound 4; then compounds 1, 3 and 2 (each within the scatter of the next).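

In this assay the aryl group on the aromatic nitrogen is not indifferent: 4-(trifluoromethyl)phenyl in place of 3-chlorophenyl gives a number 23.4 percentage points lower from compound 3 to compound 4 (beyond the scatter). The one earlier step, on an aromatic carbon, stayed within the scatter, so this is the first change shown to move the number beyond it. Nothing available here accounts for the drop.

As far as these compounds go, whether the drop follows the trifluoromethyl group itself or its place on the phenyl ring stays open, as both change in this one step. A 3-(trifluoromethyl)phenyl or 4-chlorophenyl group on that nitrogen would separate the two.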